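The compounds below may be only part of what the source reports. "The series", "measured", "known", "first", "only" and "open" are said of these compounds alone.

Measured so far:

Compound 1, `CCOc1ncc(-c2nc(C(F)(F)F)sc2N2CCN(C(=O)Cn3cnc4cccnc43)[C@H](C)C2)cn1`, gives 48 nM in an assay on blood for inhibition of C-X-C chemokine receptor type 3 (Homo sapiens), with a stated time of 30 min; a higher number here means a weaker inhibitor, a lower number a stronger inhibitor.
Compound 2, `CCOc1ncc(-c2nc(C(F)(F)F)sc2N2CCN(C(=O)Cn3c(=O)oc4ccccc43)[C@H](C)C2)cn1`, gives 536 nM in this assay.

Compound 2 holds the higher of the two numbers, so it is the weaker inhibitor of the pair. The two compounds share the same core and differ only in the aromatic group carried on the saturated chain carbon bound to the carbonyl carbon; the step of an 11-fold higher number from compound 1 to compound 2 (1.05 log units; beyond the scatter) shows that this single exchange shifts the read-out by a large amount.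

Compound 3, `CCOc1ncc(-c2nc(C(F)(F)F)sc2N2CCN(C(=O)Cn3ccc(C(F)(F)F)n3)[C@H](C)C2)cn1`, has not yet been measured. It alters the same part of the molecule: a group of 9 heavy atoms (4 carbon, 2 nitrogen, 3 fluorine; one five-membered aromatic ring with 2 hetero atoms) in place of a group of 10 heavy atoms (7 carbon, 1 nitrogen, 2 oxygen; one five-membered aromatic ring with 2 hetero atoms, one six-membered aromatic ring of carbon only), on a saturated chain carbon bound to a carbonyl carbon. Within the data shown here, the one measured step bears on it only by showing that this position is sensitive, with a large effect from one ring exchange; it gives no direction for a smaller single-ring group with a trifluoromethyl substituent. The step for compound 3 is therefore expected to be a 2.7-fold lower number from compound 2 to compound 3 (0.43 log units; beyond the scatter), with wide uncertainty. Compound 3 is estimated at 200 nM, within a range from 40 nM to 1000 nM.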

Compound 3, half-maximal inhibitory concentration: 90 nM
Compound 3: the middle estimate sits 2.2-fold (0.35 log units) above what was measured, and the stated range covers the measured number.
By their numbers in this assay, from the lowest: compounds 1 and 3 (each within the scatter of the next); then compound 2.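

Replacing the two-ring group of compound 2 with 3-(trifluoromethyl)-1H-pyrazol-1-yl gives a 6.0-fold lower number from compound 2 to compound 3 (0.77 log units; beyond the scatter) in this assay, so the weaker result of compound 2 does not apply to every group at this position. Compared with the two-ring group of compound 1, the same single-ring group gives a 1.9-fold higher number from compound 1 to compound 3 (0.27 log units; within the scatter), so compound 1 and compound 3 cannot be told apart here, and a second ring is not required to reach this level of inhibition. Nothing shown accounts for the differences among these three groups.

From the compounds shown here alone, what the trifluoromethyl group itself contributes remains open, and comparing it with a methyl group or a plain hydrogen on the same pyrazole would address this. Also open, going by these compounds, is how a carboxylic acid or an amine would behave on this saturated chain carbon.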